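Anilide sulfonamide series: swapping the aryl substituent on the anilino nitrogen

The source may hold more compounds than are shown below. What is called first, only, known or untested is meant among the compounds shown, and "the series" means these compounds.

Measured so far, in a functional assay on A-431 cells (Homo sapiens) for antiproliferative activity, read by MTT assay, with a stated time of 72 h; a higher number here means a weaker inhibitor, a lower number a stronger inhibitor:
- compound 1, `COc1cc2ncnc(Nc3ccc(Cl)cc3)c2cc1OCCCCC(=O)Nc1ccc(S(N)(=O)=O)cc1`, gives 7120 nM
- compound 2, `COc1cc2ncnc(Nc3ccc(Br)cc3)c2cc1OCCCCC(=O)Nc1ccc(S(N)(=O)=O)cc1`, gives 6570 nM
- compound 3, `COc1ccc(Nc2ncnc3cc(OC)c(OCCCCC(=O)Nc4ccc(S(N)(=O)=O)cc4)cc23)cc1`, gives 14700 nM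

Compound 2 carries the lowest number of the three in this assay, but the gap is small, a 1.1-fold lower number from compound 1 to compound 2 (0.03 log units; within the scatter), so compounds 1 and 2 cannot be ranked. Only compound 3 sits clearly apart: a 2.1-fold higher number from compound 1 to compound 3 (0.31 log units; beyond the scatter) and a 2.2-fold higher number from compound 2 to compound 3 (0.35 log units; beyond the scatter).

Compound 4, `COc1ccccc1Nc1ncnc2cc(OC)c(OCCCCC(=O)Nc3ccc(S(N)(=O)=O)cc3)cc12`, has not been measured. Relative to compound 2 the change is 2-methoxyphenyl in place of 4-bromophenyl on a nitrogen on an aromatic ring. Of the measured steps, the one that bears on it is the replacement of bromo by methoxy, a 2.2-fold higher number from compound 2 to compound 3 (0.35 log units; beyond the scatter); the halogen swap a 1.1-fold lower number from compound 1 to compound 2 (0.03 log units; within the scatter) shows nothing. Within the data shown here, no measured pair tells how moving the group to a different position on the ring acts, and no pair holds a 2-methoxyphenyl, so the step from compound 2 to compound 4 is only partly covered.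

The expectation for compound 4 is a weaker inhibitor than compound 2, with a step of about a 2.3-fold higher number from compound 2 to compound 4 (0.36 log units; beyond the scatter) in this assay, because the step of a 2.2-fold higher number from compound 2 to compound 3 (0.35 log units; beyond the scatter) points that way, and the range is widened for the untested position. Compound 4 is therefore estimated at 15000 nM, between 6000 nM and 40000 nM.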

Compound 4, half-maximal inhibitory concentration: 24200 nM
For compound 4 the middle estimate is 1.6-fold (0.21 log units) below the measured one, and the stated range covers the measured number.
By their numbers in this assay, from the lowest: compounds 2 and 1 (each within the scatter of the next); then compounds 3 and 4 (each within the scatter of the next).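

In this assay, moving the methoxy group from 4-methoxyphenyl to 2-methoxyphenyl gives a 1.6-fold higher number from compound 3 to compound 4 (0.22 log units; within the scatter), so compound 3 and compound 4 cannot be ranked, and the placement of methoxy on this ring has no readable effect in this pair. The halogen compounds remain clearly apart from the new 2-methoxyphenyl compound, with a 3.7-fold higher number from compound 2 to compound 4 (0.57 log units; beyond the scatter) and a 3.4-fold higher number from compound 1 to compound 4 (0.53 log units; beyond the scatter), so the earlier separation between the halogen and methoxy compounds now extends to a second methoxy placement. Across these four compounds, both methoxy compounds carry higher numbers than both halogen compounds, none goes against that split, and no available data account for it.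

A plain phenyl group, or a ring carrying a nitrile, an amine or a carboxylic acid, would show whether the split belongs to methoxy itself or extends to other groups on the anilino nitrogen. The compounds shown also share one chain between the core and the sulfonamide anilide, so it remains open whether the same order of groups would hold with a shorter or longer chain.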